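This account rests on a few compounds, and the source may have more. Where it says the series, first, only, none or still open, it means among the compounds named here.

Measured so far in a functional assay on HepG2 cells (Homo sapiens) for antiproliferative activity, read by MTT assay, with a stated time of 48 h; on this read-out higher numbers stand for weaker inhibition and lower numbers for stronger inhibition:
compound 1 `CCCCCCCCCCCCOc1ccc(C(=O)/C=C/c2c(/C=C/c3ccc(OC)cc3)cc(OC)cc2OC)cc1` — 11.6 ug/mL
compound 2 `COc1ccc(/C=C/c2cc(OC)cc(OC)c2/C=C/C(=O)c2cccc(OC)c2)cc1` — 11.6 ug/mL
compound 3 `COc1ccc(/C=C/c2cc(OC)cc(OC)c2/C=C/C(=O)c2cccc(Br)c2)cc1` — 13 ug/mL

Compound 3 holds the highest of the three numbers, yet its gaps to compound 1 and to compound 2 are each within the scatter, so the three compounds stand together and none can be called stronger or weaker than another.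

Compound 4 `COc1ccc(/C=C/c2cc(OC)cc(OC)c2/C=C/C(=O)c2ccc(N)cc2)cc1` is the next compound to be measured. Its change from compound 3: 4-aminophenyl in place of 3-bromophenyl on a carbonyl carbon.

For the measured compounds named here, only one measured step touches the ring attached to the carbonyl carbon: a 1.1-fold higher number from compound 2 to compound 3 (0.05 log units; within the scatter). It is within the scatter. Compound 1 carries dodecyloxy on that ring and its value sits with those of compound 2 and compound 3, so swapping groups on this ring has so far left the read-out unmoved. Going by the values given here, the amino group brings a hydrogen-bond donor and acceptor that no measured compound has, so the expectation rests on a narrow base.

For compound 4 the step of a 1.1-fold lower number from compound 3 to compound 4 (0.03 log units; within the scatter) is expected to stay within the scatter. Compound 4 is estimated at 12 ug/mL, with a range from 6 ug/mL to 25 ug/mL.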

Compound 4, half-maximal inhibitory concentration: 7.5 ug/mL
For compound 4 the middle estimate is 1.6-fold (0.20 log units) above the measured one; measured number inside the range.
By their numbers in this assay, from the lowest: compounds 4, 1, 2 and 3 (each within the scatter of the next).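

In this assay, 4-aminophenyl in place of 3-bromophenyl on a carbonyl carbon gives a 1.7-fold lower number from compound 3 to compound 4 (0.24 log units; within the scatter), and 4-aminophenyl in place of 3-methoxyphenyl gives a 1.5-fold lower number from compound 2 to compound 4 (0.19 log units; within the scatter), so neither step separates compound 4 from its neighbours. For the compounds shown here, the position thus accepts a group with a hydrogen-bond donor, which none of the earlier compounds carries, and the read-out stays within the scatter of the values for compound 2 and compound 3. No supporting measurement bears on this result.

Both steps change the group and its place on the ring together, so the compounds shown cannot separate the two. From the compounds shown here alone, whether an acetamide or a carboxylic acid on this ring would take the number beyond the scatter remains open.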